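A hydroxy group returns to the amide of compound 3

A few compounds are considered here, and "the series" means these few. Any claim that something is new, unique, unknown or untested is made for them only; others in the source may bear on it.

In a functional assay on SiHa cells (Homo sapiens) for inhibition, read by CCK-8 assay, with a stated time of 72 h, tested at 1 uM (a higher number here means more inhibition of growth at the concentration tested, a lower number less inhibition of growth), compound 3 (`CN(C)C(=O)c1cc2cnc(Nc3ccc(NC(=O)C4(C(=O)Nc5cccc(Cl)c5)CC4)cc3)nc2n1C1CCCC1`) gives 16.2%, the second highest of three measured numbers. The highest number belongs to compound 2 (`CN(C)C(=O)c1cc2cnc(Nc3ccc(NC(=O)C4(C(=O)Nc5ccccc5F)CC4)cc3)nc2n1C1CCCC1`) at 63.4%. The lowest number belongs to compound 1 (`CN(C)C(=O)c1cc2cnc(Nc3ccc(NC(=O)C4(C(=O)Nc5cccc(O)c5)CC4)cc3)nc2n1C1CCCC1`) at -19.8%. The gaps around it are a number 47.2 percentage points lower from compound 2 to compound 3 (beyond the scatter) and a number 36 percentage points higher from compound 1 to compound 3 (beyond the scatter), both beyond the scatter.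

Compound 4 (`CN(C)C(=O)c1cc2cnc(Nc3ccc(NC(=O)C4(C(=O)Nc5ccc(O)cc5)CC4)cc3)nc2n1C1CCCC1`) has not yet been measured. It carries 4-hydroxyphenyl in place of 3-chlorophenyl on an amide-type nitrogen.

The closest guide is a number 36 percentage points higher from compound 1 to compound 3 (beyond the scatter), a large step with chloro in place of hydroxy on an aromatic carbon. The change to compound 4 runs the other way, from a chlorinated ring to a hydroxylated one, so a fall is the likelier direction. Among the compounds with values here, the guide is imperfect, since no measured compound carries the 4-hydroxyphenyl group. The data also show that this aryl group can move the number widely, as in a number 83.2 percentage points higher from compound 1 to compound 2 (beyond the scatter), so the uncertainty is broad. A moderate drop, smaller than the guiding step, is therefore expected, and the estimated change is a number 16.2 percentage points lower from compound 3 to compound 4 (beyond the scatter). For compound 4 the expected value is 0%, with an estimated range from -25% to 30%.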

Compound 4, percent growth inhibition at one concentration: 69.5%
Estimate against measurement, compound 4: 69.5 percentage points below; measured number outside the range, above it.
By their numbers in this assay, from the lowest: compound 1; then compound 3; then compounds 2 and 4 (each within the scatter of the next).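

In this assay, a hydroxy group on this aryl ring does not by itself keep the number low: 4-hydroxyphenyl in place of 3-hydroxyphenyl on the amide-type nitrogen gives a number 89.3 percentage points higher from compound 1 to compound 4 (beyond the scatter) and so shows that the outcome depends on where the hydroxy group sits on the ring. The earlier advantage of chloro over hydroxy therefore holds only for the pair that shares the substitution position, since 4-hydroxyphenyl in place of 3-chlorophenyl gives a number 53.3 percentage points higher from compound 3 to compound 4 (beyond the scatter) in the opposite direction, while 4-hydroxyphenyl in place of 2-fluorophenyl gives a number 6.1 percentage points higher from compound 2 to compound 4 (within the scatter) and leaves those two groups indistinguishable in this read-out. Nothing available explains this dependence on ring position.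

The compounds shown change both the substituent and its ring position together among the chloro, fluoro and hydroxy groups, so 4-chlorophenyl, 4-fluorophenyl and 2-hydroxyphenyl would be needed to separate those two factors. As far as these compounds go, it also remains open whether the high number needs the hydroxy group itself or would persist with 4-methoxyphenyl or 4-aminophenyl on the amide-type nitrogen.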